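The compounds below may be only part of what the source reports. "The series", "measured", "known", "first", "only" and "open" are said of these compounds alone.

Measured compounds so far:
- compound 1 `Nc1nc(Cl)c2ncn(Cc3ccc(CCl)cc3)c2n1` gives > 100000 nM in a functional assay on SK-MEL-28 cells (Homo sapiens) for cytotoxicity, read by sulforhodamine B assay, with a stated time of 48 h; a higher number here means that more compound is tolerated, a lower number that less compound is tolerated; this is a limit of the assay, not a number.
- compound 2 `ClCc1cccc(Cn2cnc3c(Cl)nc(Cl)nc32)c1` gives > 100000 nM in this assay; this too is a limit, not a number.
- compound 3 `ClCc1ccc(Cn2cnc3c(Cl)nc(Cl)nc32)cc1` gives 46800 nM in this assay.

Compound 3 is the only one of the three with a number rather than a limit. Going by the values given here, the one counted step among the measured compounds is the change from compound 3 to compound 1, (amino in place of chloro on an aromatic carbon), which gives an at least 2.1-fold higher number from compound 3 to compound 1 (0.32 log units; beyond the scatter). Compound 2 and compound 3 carry the same atoms joined differently; the difference between the two cores is not broken down here.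

Compound 4 `Nc1nc(Cl)c2ncn(Cc3cccc(CCl)c3)c2n1` is not yet measured in this assay. It stands to compound 2 as compound 1 stands to compound 3: the change is amino in place of chloro on an aromatic carbon, and the place descriptions of the two changes agree word for word, so it is the same change. The reference point differs: the starting value of compound 2 is a limit rather than a number. Since the same change moved the number upward from compound 3 to compound 1, and because the limit of > 100000 nM in this assay, at which 2 of the 3 values shown sit, already holds the value of compound 2, compound 4 is expected to sit at or beyond that limit, with an expected step that the limit leaves unreadable from compound 2 to compound 4, which cannot be resolved by the assay. The estimate for compound 4 in this assay is 150000 nM, spanning 70000 nM to 500000 nM, most likely returned as a limit only.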

Compound 4, concentration lethal to 50% of the cells: 74100 nM
Compound 4: middle estimate off by 2.0-fold (0.31 log units), on the high side, within the range that was stated.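

In this assay the change to amino in place of chloro, on the aromatic carbon between two ring nitrogen atoms, gives an at least 1.3-fold lower number from compound 2 to compound 4 (0.13 log units; that floor lies within the scatter) and the floor of this step stays within the scatter. Set beside the earlier step, it shows that the change does not carry over as one fixed step from one core to the other, the gap between the two steps lying beyond the scatter: the same change on two cores in this assay, an at least 2.1-fold higher number (0.32 log units; beyond the scatter) from compound 3 to compound 1 and an at least 1.3-fold lower number (0.13 log units; that floor lies within the scatter) from compound 2 to compound 4, at least 2.8-fold (0.45 log units) apart, beyond the scatter of two such steps. It does not show the true size of either step or why the two cores part, and each step has a limit at one end: the limit of > 100000 nM in this assay, at which 2 of the 4 values shown sit.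

Going by these compounds alone, only two matched pairs carry this change, so how other groups on that same carbon, such as a methoxy group or a dimethylamino group, would behave on each core stays open. Also open, going by these compounds, is whether the two cores would still part with a hydroxymethyl group in place of the chloromethyl group.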